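Shortening the side chain of compound 3 to methyl

The source may hold more compounds than are shown below. What is called first, only, known or untested is meant among the compounds shown, and "the series" means these compounds.

Compounds 1, 2 and 3 share one core and differ at two places. Compound 1 `COC(=O)[C@H](Cc1cccc(C(=N)N)c1)[C@@H](C)NC(=O)c1ccc(-c2cccc(C(N)=O)c2)cc1` gives 90 nM in an assay on isolated protein for inhibition of serine protease 1 (Homo sapiens); a higher number here means a weaker inhibitor, a lower number a stronger inhibitor; compound 2 `COC(=O)[C@H](Cc1cccc(C(=N)N)c1)[C@@H](C)NC(=O)c1ccc(-c2ccc(C(N)=O)cc2)cc1` gives 42 nM. Going by the values given here, the only single-point step measured so far is a 2.1-fold lower number from compound 1 to compound 2 (0.33 log units; beyond the scatter). Compound 3 `COC(=O)[C@H](Cc1cccc(C(=N)N)c1)[C@@H](CC1CCCCC1)NC(=O)c1ccc(-c2cccc(CN)c2)cc1` gives 36 nM, the lowest of the three numbers; its gap to compound 2 lies within the scatter, its gap to compound 1 beyond it.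

Compound 4 `CC[C@@H](NC(=O)c1ccc(-c2cccc(CN)c2)cc1)[C@@H](Cc1cccc(C(=N)N)c1)C(=O)OC` differs from compound 3 by one change: methyl in place of cyclohexyl on a saturated chain carbon, two bonds along the chain from an amide-type nitrogen. Among the compounds with values here, no measured step touches this carbon; the one step in hand concerns the carbamoylphenyl position and says nothing about the saturated chain. The expectation for compound 4 therefore rests on the structural change alone, with a wide range. The step of a 4.2-fold higher number from compound 3 to compound 4 (0.62 log units; beyond the scatter) is the estimate taken here, leaning towards a weaker inhibitor, but with the scatter band well inside the range. For compound 4 the value in this assay is estimated at 150 nM, between 40 nM and 600 nM.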

Compound 4, inhibition constant: 63 nM
Compound 4: the middle estimate sits 2.4-fold (0.38 log units) above what was measured; the measured number falls inside the stated range.
By their numbers in this assay, from the lowest: compounds 3, 2, 4 and 1 (each within the scatter of the next, the first and the last beyond it).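

In this assay, methyl in place of cyclohexyl on a saturated chain carbon, two bonds along the chain from an amide-type nitrogen, gives a 1.8-fold higher number from compound 3 to compound 4 (0.24 log units; within the scatter). Going by these compounds alone, this is the first reading at this carbon, and it shows that, with the rest of compound 3 held fixed, taking away a ring of 6 heavy atoms leaves a number that cannot be told apart from the starting one, so in this pair the cyclohexyl is not needed for a value in this range. No supporting data bear on why the step is this small.

Within the data shown here, the pair covers only two groups at this carbon, so it remains open whether a longer chain, a phenyl ring, a hydroxyl, an amine or a carboxylic acid there would also leave the number unchanged. As far as these compounds go, compound 1 and compound 2 differ from compound 4 in more than one place, so it also remains open whether the same tolerance holds when the carbamoylphenyl groups of those two compounds are present.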